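From 3,4-dimethoxyphenyl to 4-aminophenyl on a long-chain amide

A few compounds are considered here, and "the series" means these few. Any claim that something is new, unique, unknown or untested is made for them only; others in the source may bear on it.

In a functional assay on cells (Homo sapiens) for antiproliferative activity, read by sulforhodamine B assay, with a stated time of 48 h (a lower number here means a stronger inhibitor, a higher number a weaker inhibitor), compound 1 `CCCCCCCCCCCCNC(=O)[C@@H]1CSC(c2ccc(OC)c(OC)c2)N1` gives 2900 nM and compound 2 `CCCCCCCCCCCCCCCCNC(=O)[C@@H]1CSC(c2ccc(OC)c(OC)c2)N1` gives 1500 nM in the same test. Butyl in place of hydrogen on a saturated chain carbon makes a 1.9-fold lower number from compound 1 to compound 2 (0.29 log units; within the scatter) here, so compound 2 stands level with compound 1, the only other number available.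

Compound 3 `CCCCCCCCCCCCCCCCNC(=O)[C@@H]1CSC(c2ccc(N)cc2)N1` keeps the chain of compound 2 but carries 4-aminophenyl in place of 3,4-dimethoxyphenyl on a saturated ring carbon. Within the data shown here, the one measured step concerns the chain alone, so it offers no direct guide to this ring change, and no measured pair of compounds differs in this group. The data therefore point in neither direction, and the expectation starts from compound 2 at 1500 nM as the closest measured relative. The expected move is no change at the digits printed from compound 2 to compound 3 (within the scatter) in this assay, which means no shift beyond the scatter is foreseen, though with real uncertainty. The estimate for compound 3 is 1500 nM, expected to fall between 400 nM and 5500 nM as a deliberately wide range.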

Compound 3, half-maximal inhibitory concentration: 2300 nM
For compound 3 the middle estimate is 1.5-fold (0.19 log units) below the measured one, and the stated range covers the measured number.
By their numbers in this assay, from the lowest: compounds 2, 3 and 1 (each within the scatter of the next).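

In this assay, placing 4-aminophenyl instead of 3,4-dimethoxyphenyl on the saturated ring carbon, next to the ring nitrogen and next to the ring sulfur, gives a 1.5-fold higher number from compound 2 to compound 3 (0.19 log units; within the scatter). Among these compounds, this is the first look at this position, as the earlier pair differed only in the chain, and the numbers stay within the scatter even though the two groups differ in their counts of heavy atoms, hydrogen-bond donors and hydrogen-bond acceptors. No measurement at hand speaks to the reason for this result.

This single step replaces both methoxy groups and adds the amine at once, so it cannot separate what each of these edits does, and plain phenyl, 4-methoxyphenyl or 4-hydroxyphenyl at the same carbon would be needed to pull them apart. Going by these compounds, it also remains open whether a group such as 4-nitrophenyl or a carboxylic acid on the ring, which differ more from the two groups seen here, would move the number beyond the scatter.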